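A few compounds are considered here, and "the series" means these few. Any claim that something is new, unique, unknown or untested is made for them only; others in the source may bear on it.

Of the compounds shown here, three of one series have been tested in an ADME assay on MT4 cells (Homo sapiens) for cytotoxicity, read by MTT assay, with a stated time of 5 days; on this read-out lower numbers stand for higher toxicity in this test and higher numbers for lower toxicity in this test. Compound 1 has the structure `O=[N+]([O-])c1ccc(-c2nnc(-c3cccnc3)n2Nc2nc3ccc([N+](=O)[O-])cc3s2)cc1` and in this assay compound 1 gives 50.8 ug/mL. Compound 2, `O=[N+]([O-])c1ccc(-c2nnc(-c3cccnc3)n2Nc2nc3ccc(Cl)cc3s2)cc1`, differs from compound 1 by chloro in place of nitro on an aromatic carbon; in this assay compound 2 gives 53.7 ug/mL, so this change brought a 1.1-fold higher number from compound 1 to compound 2 (0.02 log units; within the scatter). Compound 3, `O=[N+]([O-])c1ccc(-c2nnc(-c3cccnc3)n2Nc2nc3c([N+](=O)[O-])cccc3s2)cc1`, is built from the same atoms as compound 1, joined differently; the difference between the two cores is not broken down here. In this assay compound 3 gives 13.8 ug/mL, the lowest of the three numbers, and its gaps to compound 1 and to compound 2 both lie beyond the scatter of the test.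

Compound 4, `O=[N+]([O-])c1ccc(-c2nnc(-c3cccnc3)n2Nc2nc3c(Cl)cccc3s2)cc1`, has not yet been measured. It differs from compound 3 by chloro in place of nitro on an aromatic carbon. This is the same kind of change as the one from compound 1 to compound 2, which occurs twice among the compounds shown, though the place is not the same: in compound 1 the leaving nitro is meta to a fused ring and para to a fused ring, whereas in compound 3 it is ortho to a fused ring and meta to a fused ring. The step from compound 3 to compound 4 is expected to be a 1.1-fold higher number from compound 3 to compound 4 (0.04 log units; within the scatter), because the corresponding earlier change produced a 1.1-fold higher number from compound 1 to compound 2 (0.02 log units; within the scatter). Compound 4 is accordingly estimated to give about 15 ug/mL in this assay, with an expected range from 8 ug/mL to 30 ug/mL.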

Compound 4, half-maximal cytotoxic concentration: 15.6 ug/mL
Estimate against measurement, compound 4: 1.0-fold (0.02 log units) below; the range from low to high includes it.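

In this assay, chloro in place of nitro on the core of compound 3 gave a 1.1-fold higher number from compound 3 to compound 4 (0.05 log units; within the scatter), and this step agrees with the earlier one on the core of compound 1: the same change on two cores in this assay, a 1.1-fold higher number (0.02 log units; within the scatter) from compound 1 to compound 2 and a 1.1-fold higher number (0.05 log units; within the scatter) from compound 3 to compound 4, 1.1-fold (0.03 log units) apart, within the scatter of two such steps. The place of the chloro is a separate matter, since 4-chloro-1,3-benzothiazol-2-yl in place of 6-chloro-1,3-benzothiazol-2-yl gave a 3.4-fold lower number from compound 2 to compound 4 (0.54 log units; beyond the scatter), a step beyond the scatter, so the exchange of nitro for chloro carried across the two cores while the difference between the two chloro compounds remained. Among these compounds, this shows only that the exchange made no readable difference in this test on these two cores; with just two pairs, and both steps within the scatter, it does not show that the same would hold on any further core, nor does it separate a small effect from none.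

The compounds shown leave open whether a different group at these two places, such as an amine, a methoxy group or a carboxylic acid, would also leave the number unchanged. They also leave open whether the step would hold if the rest of the molecule, which stays the same in all four compounds, were altered.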